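This account rests on a few compounds, and the source may have more. Where it says the series, first, only, none or still open, it means among the compounds named here.

Measured in an ADME assay on cells (Hepatocyte, Homo sapiens) for metabolic stability, with a stated time of 30 min; a lower number here means that less of the compound is left, a higher number that more of the compound is left:
- Compound 1 `CS(=O)(=O)NC1CCC(CN2CCN(c3cc(=O)c4cc(C(F)(F)F)cc([N+](=O)[O-])c4s3)CC2)CC1`: 105%
- Compound 2 `Cc1ccc(C(=O)OC2CCC(CN3CCN(c4cc(=O)c5cc(C(F)(F)F)cc([N+](=O)[O-])c5s4)CC3)CC2)cc1`: 9.7%
- Compound 3 `CC(=O)OC1CCC(CN2CCN(c3cc(=O)c4cc(C(F)(F)F)cc([N+](=O)[O-])c4s3)CC2)CC1`: 0%

Compound 3 stands together with compound 2 at the low end of this small set, with a number 9.7 percentage points lower from compound 2 to compound 3 (within the scatter). It lies far from compound 1, with a number 105 percentage points lower from compound 1 to compound 3 (beyond the scatter). Compound 4 `CC(=O)NC1CCC(CN2CCN(c3cc(=O)c4cc(C(F)(F)F)cc([N+](=O)[O-])c4s3)CC2)CC1` keeps the shared core and has acetamido in place of acetoxy on a saturated ring carbon.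

Among the compounds with values here, no measured step makes this exact exchange. The closest evidence is the pair of large steps a number 95.3 percentage points lower from compound 1 to compound 2 (beyond the scatter) and a number 105 percentage points lower from compound 1 to compound 3 (beyond the scatter), both of which leave methanesulfonamido for a carbonyl-bearing oxy group. The change of the group on the carbonyl carbon, seen in a number 9.7 percentage points lower from compound 2 to compound 3 (within the scatter), stayed small. Compound 4 returns to an amido group like that of compound 1, so a large rise in this assay is expected, although its size remains uncertain without a measured acetamido compound. The expected change is a number 80 percentage points higher from compound 3 to compound 4 (beyond the scatter). For compound 4 the estimated value is 80%, within an expected range of 45% to 105%.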

Compound 4, percent of the compound remaining: 86.8%
For compound 4 the middle estimate is 6.8 percentage points below the measured one; low and high end bracket the measured number.
By their numbers in this assay, from the lowest: compounds 3 and 2 (each within the scatter of the next); then compound 4; then compound 1.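

In this assay, the direct exchange of acetoxy for acetamido on the saturated ring carbon gives a large rise (a number 86.8 percentage points higher from compound 3 to compound 4 (beyond the scatter)), and the step from the larger carbonyl-bearing oxy group is also large (a number 77.1 percentage points higher from compound 2 to compound 4 (beyond the scatter)), so among these compounds the two amide-linked groups stand apart from the two oxy-linked ones. The group on the amine nitrogen still matters, although with acetyl in place of methylsulfonyl the step is only modest (a number 18.2 percentage points lower from compound 1 to compound 4 (beyond the scatter)). Nothing measured here explains these differences.

As far as these compounds go, what stays open is whether a longer chain on the carbonyl, such as propanoyl, or a benzoyl group on the amine nitrogen would hold this level. From the compounds shown here alone, it is equally open whether a free amine or a carboxylic acid on the same ring carbon would fall with the amide-linked or the oxy-linked groups.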